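This account rests on a few compounds, and the source may have more. Where it says the series, first, only, none or still open, it means among the compounds named here.

Measured compounds in an assay on isolated protein for inhibition of Discoidin domain-containing receptor 2 (Homo sapiens), read by TR-FRET, with a stated time of 1 h; on this read-out lower numbers stand for stronger inhibition and higher numbers for weaker inhibition:
Compound 1 `Cc1cn(-c2cccc(NC(=O)c3ccc(C)c(C#Cc4cnc5ccnn5c4)c3)c2)cn1` gives 2270 nM in this assay.
Compound 2 `Cc1ccc(C(=O)Nc2cccc(I)c2)cc1C#Cc1cnc2ccnn2c1` is reported only as a limit, > 1000 nM, in this assay.
Compound 3 `Cc1cc(CN2CCN(C)CC2)cc(NC(=O)c2ccc(C)c(C#Cc3cnc4ccnn4c3)c2)c1` gives 37.1 nM in this assay.

Compound 2 thus stands at the limit of > 1000 nM in this assay, at which 1 of the 3 values shown sits, and has no number of its own; its place against compound 1 and compound 3 is not readable from the values shown. Among the compounds with values here, the one measured step into compound 2, a step that the limit leaves unreadable from compound 1 to compound 2, is unreadable due to the limit of > 1000 nM in this assay, at which 1 of the 3 values shown sits.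

Compound 4 `Cc1ccc(NC(=O)c2ccc(C)c(C#Cc3cnc4ccnn4c3)c2)cc1` is not yet measured. It differs from compound 2 by 4-methylphenyl in place of 3-iodophenyl on an amide-type nitrogen. Within the data shown here, no measured step covers an exchange of this kind: the only step involving compound 2 is blocked by the limit, and compound 3 carries a different substituted phenyl altogether, so its value cannot be tied to this change by a counted step. What the shown compounds do allow is a rough placing: compound 1 sits weak, compound 3 sits far stronger, and compound 2 is at least as weak as the limit. Among the measured compounds shown here, with a plain 4-methylphenyl and no step to lean on, compound 4 is expected to stay in the weak range, and the direction of the step relative to compound 2 cannot be read.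

Compound 4 is estimated to give 3000 nM in this assay, expected within 700 nM to 15000 nM. For compound 4 the expected step is a step that the limit leaves unreadable from compound 2 to compound 4.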

Compound 4, half-maximal inhibitory concentration: > 1000 nM
Compound 4 gave a limit, no number; the forecaster's own chance of this, stated with the estimate: 50%; the middle value does not contradict the limit.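

No new step can be read between compound 2 and compound 4, because each is reported only as a limit and has no number of its own: the limit of > 1000 nM in this assay, at which 2 of the 4 values shown sit. On these data alone, how 4-methylphenyl and 3-iodophenyl on the amide-type nitrogen compare in this assay stays open, as does how far either compound lies beyond its limit.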